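Chain Length and Branching at the Ether Oxygen

This account rests on a few compounds, and the source may have more. Where it says the series, first, only, none or still open, it means among the compounds named here.

In a functional assay on KB cells (Homo sapiens) for cytotoxicity, read by MTT assay, with a stated time of 72 h (on this read-out higher numbers stand for weaker inhibition and lower numbers for stronger inhibition), three compounds sharing one core have been measured:

Compound 1, `[O-][n+]1nc(NCOC2CCCCC2)[n+]([O-])c2ccccc21`, gives 22100 nM.
Compound 2, `CCCCCOCNc1n[n+]([O-])c2ccccc2[n+]1[O-]`, gives 39500 nM.
Compound 3, `CCCOCNc1n[n+]([O-])c2ccccc2[n+]1[O-]`, gives 10200 nM.

Compound 3 stands at the lowest number of the three in this assay. Both measured steps that end at it run downward and lie beyond the scatter: a 2.2-fold lower number from compound 1 to compound 3 (0.34 log units; beyond the scatter) and a 3.9-fold lower number from compound 2 to compound 3 (0.59 log units; beyond the scatter). The remaining step, a 1.8-fold higher number from compound 1 to compound 2 (0.25 log units; within the scatter), stays within the scatter, so compound 1 and compound 2 cannot be set in order against each other.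

Compound 4, `CC(C)CCOCNc1n[n+]([O-])c2ccccc2[n+]1[O-]`, differs from compound 3 by isopropyl in place of methyl on a saturated chain carbon, two bonds along the chain from an oxygen on a saturated carbon. It therefore carries the same count of chain carbons as compound 2, but with a branch. The step that bears most directly on this change is a 3.9-fold lower number from compound 2 to compound 3 (0.59 log units; beyond the scatter), which shows that shortening the chain lowered the number; the present change runs the other way and adds a branch besides. The step of a 2.2-fold lower number from compound 1 to compound 3 (0.34 log units; beyond the scatter) points the same way, a larger group giving a higher number. Nothing here separates a branched from a straight chain of equal length, so the expectation rests on chain size alone.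

Compound 4 is therefore expected to show a modest rise, a 2.5-fold higher number from compound 3 to compound 4 (0.39 log units; beyond the scatter). Compound 4 is estimated at 25000 nM, with a range from 10000 nM to 60000 nM.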

Compound 4, half-maximal inhibitory concentration: 5210 nM
Compound 4: the middle estimate sits 4.8-fold (0.68 log units) above what was measured; measured number below the stated range.
By their numbers in this assay, from the lowest: compounds 4 and 3 (each within the scatter of the next); then compounds 1 and 2 (each within the scatter of the next).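

In this assay, isopropyl in place of methyl on a saturated chain carbon, two bonds along the chain from an oxygen on a saturated carbon, gives a 2.0-fold lower number from compound 3 to compound 4 (0.29 log units; within the scatter) and so compound 3 and compound 4 cannot be set in order against each other. Among the compounds shown here, the branch does separate isopentyl from pentyl, a difference the earlier compounds could not show: a 7.6-fold lower number from compound 2 to compound 4 (0.88 log units; beyond the scatter) places the branched chain clearly apart from the straight one, and compound 4 therefore goes against the reading that a larger group gives a higher number. The same holds against cyclohexyl, with a 4.2-fold lower number from compound 1 to compound 4 (0.63 log units; beyond the scatter) setting isopentyl with propyl and apart from both pentyl and cyclohexyl in this series.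

No measurement beyond these cytotoxicity numbers bears on what lies behind the gap between pentyl and isopentyl. The compounds shown leave open whether isobutyl, a longer branched chain or an amine on the chain would stay with compound 3 and compound 4 or move toward compound 2.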